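The compounds below may be only part of what the source reports. "The series", "measured", "known", "first", "only" and "open" are said of these compounds alone.

Measured compounds:
compound 1 `COc1cc(C(=O)N/N=C/c2cccc(F)c2)cc(OC)c1OC` – 53.5%
compound 2 `COc1cc(C(=O)N/N=C/c2ccc(F)cc2)cc(OC)c1OC` – 76%
compound 3 `COc1cc(C(=O)N/N=C/c2ccccc2F)cc(OC)c1OC` – 70.6%

In a functional assay on PC-3 cells (Homo sapiens) for antiproliferative activity, read by MTT assay, tested at 1 uM (a lower number here means a weaker effect, a higher number a stronger effect of the compound at the concentration tested), compound 3 stands second highest of the three numbers. Its nearest neighbour is compound 2, the step of a number 5.4 percentage points lower from compound 2 to compound 3 (within the scatter) being within the scatter, so no order between these two can be read. Its furthest neighbour is compound 1, with a number 17.1 percentage points higher from compound 1 to compound 3 (beyond the scatter) beyond the scatter.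

Compound 4 `COc1cc(C(=O)N/N=C/c2ccc(Cl)c(Cl)c2)cc(OC)c1OC` is the next member. Its change from compound 3: 3,4-dichlorophenyl in place of 2-fluorophenyl on a carbon with a double bond to nitrogen

Among the measured compounds shown here, no measured step bears directly on this change. All three measured steps exchange one fluorophenyl for another on the same carbon: a number 22.5 percentage points higher from compound 1 to compound 2 (beyond the scatter) and a number 17.1 percentage points higher from compound 1 to compound 3 (beyond the scatter) are both modest and beyond the scatter, while a number 5.4 percentage points lower from compound 2 to compound 3 (within the scatter) lies within it. None of them involves chlorine or a ring carrying two halogens, so the measured series gives no direction for the entering 3,4-dichlorophenyl. The expectation for compound 4 is therefore no step beyond the scatter, a number 2.6 percentage points lower from compound 3 to compound 4 (within the scatter), with a wide range to reflect the missing precedent. Compound 4 is estimated at 68%, between 45% and 88%.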

Compound 4, a percentage reported as inhibition, at one concentration (the size of the read-out at that concentration, not a potency): 13.5%
For compound 4 the middle estimate is 54.5 percentage points above the measured one; measured number outside the range, below it.
By their numbers in this assay, from the lowest: compound 4; then compound 1; then compounds 3 and 2 (each within the scatter of the next).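

In this assay, the group on the carbon with a double bond to nitrogen proves far less forgiving than the fluorophenyl exchanges suggested: 3,4-dichlorophenyl gives a number 57.1 percentage points lower from compound 3 to compound 4 (beyond the scatter) and a number 62.5 percentage points lower from compound 2 to compound 4 (beyond the scatter) and also a number 40 percentage points lower from compound 1 to compound 4 (beyond the scatter) as the three steps to the fluorophenyl compounds. All three exceed the largest step among the fluorophenyl compounds, a number 22.5 percentage points higher from compound 1 to compound 2 (beyond the scatter) in this series, so compound 4 stands clearly apart from compounds 1, 2 and 3. No measurement available here explains this loss of effect.

The change replaces fluorine with chlorine and also adds a second halogen, and these two differences remain unseparated. A 4-chlorophenyl or 3,4-difluorophenyl group would separate them, while a ring bearing an amine or a carboxylic acid would test whether non-halogen groups are accepted here.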